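Adding a methyl to a weakly cytotoxic sulfone

The source may hold more compounds than are shown below. What is called first, only, known or untested is meant among the compounds shown, and "the series" means these compounds.

compound 1 `O=S(=O)(c1ccccc1)c1nc2ccccc2nc1Nc1ccc(F)cc1` gives > 50000 nM
compound 2 `O=S(=O)(c1ccccc1)c1nc2ccccc2nc1Nc1ccc(Cl)cc1` gives 41200 nM

In a functional assay on KB cells (Homo sapiens) for cytotoxicity, read by MTT assay, with a stated time of 72 h (a lower number here means a stronger inhibitor, a higher number a weaker inhibitor), compound 1 gives > 50000 nM as a limit of the assay, not a number. Compound 3 `Cc1ccc(S(=O)(=O)c2nc3ccccc3nc2Nc2ccc(F)cc2)cc1` differs from it by methyl in place of hydrogen on an aromatic carbon with methyl in place of hydrogen on an aromatic carbon. Among the compounds with values here, the only measured step is an at least 1.2-fold lower number from compound 1 to compound 2 (0.08 log units; that floor lies within the scatter) and its floor lies within the scatter, while it changes a different group. No step beyond the scatter is therefore expected in this assay from the methyl. The estimate means an expected a number no higher from compound 1 to compound 3 (the limit leaves the size open) and no more. Compound 3 is expected at 50000 nM (estimated range 20000 nM to 100000 nM).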

Compound 3, half-maximal inhibitory concentration: 8950 nM
Compound 3: middle estimate off by 5.6-fold (0.75 log units), on the high side; the measured number lies below the stated range.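

In this assay, changing phenyl to 4-methylphenyl gives an at least 5.5-fold lower number from compound 1 to compound 3 (0.74 log units; beyond the scatter) and so moves the number beyond the scatter, which the earlier swap of fluoro for chloro did not show. Within the data shown here, this single added methyl is therefore the first change here with a clear effect. Its step is only a floor, since compound 1 stands at a limit: the limit of > 50000 nM in this assay, at which 1 of the 3 values shown sits.

From the compounds shown here alone, whether methyl is special stays open, as an ethyl, a methoxy or an amine in its place could give a different step. Going by these compounds, whether methyl acts the same way on compound 2 also stays open.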